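The source may hold more compounds than are shown below. What is called first, only, known or untested is meant among the compounds shown, and "the series" means these compounds.

Measured compounds:
compound 1 `Cc1cc2c(cc1Cc1ccc(C(=O)NCC3CCCCC3)o1)C(C)(C)CCC2(C)C`: 1550 nM
compound 2 `Cc1cc2c(cc1Cc1ccc(C(=O)NCC3CCC(CN)CC3)o1)C(C)(C)CCC2(C)C`: 730 nM

In an assay on isolated protein for binding affinity to Gonadotropin-releasing hormone receptor (Rattus norvegicus) (on this read-out higher numbers stand for weaker inhibition and lower numbers for stronger inhibition), compound 1 gives 1550 nM and compound 2 gives 730 nM. For the measured compounds named here, compound 2 therefore holds the lowest of the two numbers measured, and the only step between them, a 2.1-fold lower number from compound 1 to compound 2 (0.33 log units; beyond the scatter), is a modest one that places aminomethyl in place of hydrogen on a saturated ring carbon.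

Compound 3 `Cc1cc2c(cc1Cc1ccc(C(=O)NCC3CCC(CNC(=O)C(F)(F)F)CC3)o1)C(C)(C)CCC2(C)C` has not been measured in this assay. It differs from compound 2 in one place: (trifluoromethyl)carbonyl in place of hydrogen on an amine nitrogen. Going by the values given here, no measured step bears directly on a substituent entering on the amine nitrogen; the single step known, a 2.1-fold lower number from compound 1 to compound 2 (0.33 log units; beyond the scatter), concerns only the arrival of the amine itself. With the aminomethyl group retained but its nitrogen now carrying (trifluoromethyl)carbonyl, the step from compound 2 to compound 3 is expected to be small, either none beyond the scatter or a modest move toward a higher number, a 1.6-fold higher number from compound 2 to compound 3 (0.22 log units; within the scatter). Compound 3 is accordingly estimated at 1200 nM, within a range of 400 nM to 3500 nM.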

Compound 3, inhibition constant: 2720 nM
Compound 3: middle estimate off by 2.3-fold (0.36 log units), on the low side, and the stated range covers the measured number.
By their numbers in this assay, from the lowest: compound 2; then compounds 1 and 3 (each within the scatter of the next).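

In this assay, placing (trifluoromethyl)carbonyl on the amine nitrogen gives a 3.7-fold higher number from compound 2 to compound 3 (0.57 log units; beyond the scatter), which shows that this nitrogen tolerates substitution poorly enough to undo the modest improvement seen earlier with the free aminomethyl group, a 2.1-fold lower number from compound 1 to compound 2 (0.33 log units; beyond the scatter). Set against the unsubstituted saturated ring, the complete (((trifluoromethyl)carbonyl)amino)methyl group gives a 1.8-fold higher number from compound 1 to compound 3 (0.24 log units; within the scatter), so on these numbers the capped side chain cannot be told apart from plain hydrogen on that ring carbon. Nothing available here accounts for the effect of this change on the nitrogen.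

The compounds shown do not separate the contribution of the carbonyl from that of the trifluoromethyl group, a question that an acetyl group or a simple methyl group on the same nitrogen would address. They also leave open how the number responds to a longer chain between the saturated ring and the amine, or to a carboxylic acid in place of the amine.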